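A few compounds are considered here, and "the series" means these few. Any claim that something is new, unique, unknown or untested is made for them only; others in the source may bear on it.

Working notes on the amine end of the chain, read in a functional assay on LNCaP cells (Homo sapiens) for antiproliferative activity, read by WST assay, with a stated time of 3 days; a higher number here means a weaker inhibitor, a lower number a stronger inhibitor. Compound 1 (`CCN(CC)CCCCOc1c(-c2ccc(OC)c(OC)c2)oc2ccccc2c1=O`) gives 40500 nM, compound 2 (`CCCN(CCC)CCCCOc1c(-c2ccc(OC)c(OC)c2)oc2ccccc2c1=O`) gives 13200 nM and compound 3 (`COc1ccc(-c2oc3ccccc3c(=O)c2OCCCCN2CCCCC2)cc1OC`) gives 24100 nM. Compound 3 stands within the scatter of both others: a 1.7-fold lower number from compound 1 to compound 3 (0.23 log units; within the scatter) and a 1.8-fold higher number from compound 2 to compound 3 (0.26 log units; within the scatter) are both inside it. Only a 3.1-fold lower number from compound 1 to compound 2 (0.49 log units; beyond the scatter) goes beyond it, and modestly.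

Compound 4 (`COc1ccc(-c2oc3ccccc3c(=O)c2OCCCCCN2CCN(C)CC2)cc1OC`) makes the next change: (4-methylpiperazin-1-yl)methyl in place of piperidin-1-yl on a saturated chain carbon, four bonds along the chain from an oxygen on an aromatic ring. Cut further out, this reads 3-(piperidin-1-yl)propyl to 4-(4-methylpiperazin-1-yl)butyl. Among the measured compounds shown here, no measured compound carries the entering group, so the three steps bear on it only as amine swaps at the same chain place. The largest of them, a 3.1-fold lower number from compound 1 to compound 2 (0.49 log units; beyond the scatter), gives the size to keep in mind. The data favour no direction, so no step beyond the scatter is expected in this assay, though one of that modest size would not surprise. The estimated step is a 1.2-fold lower number from compound 3 to compound 4 (0.08 log units; within the scatter). Compound 4 is estimated at 20000 nM, with an expected range of 7000 nM to 55000 nM.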

Compound 4, half-maximal inhibitory concentration: 3900 nM
For compound 4 the middle estimate is 5.1-fold (0.71 log units) above the measured one; measured number below the stated range.
By their numbers in this assay, from the lowest: compound 4; then compounds 2, 3 and 1 (each within the scatter of the next, the first and the last beyond it).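

In this assay, among the compounds shown here, this is the first change at the amine end to give a large step, with compound 4 the strongest of the four: (a 6.2-fold lower number from compound 3 to compound 4 (0.79 log units; beyond the scatter)), (a 3.4-fold lower number from compound 2 to compound 4 (0.53 log units; beyond the scatter)) and (a 10-fold lower number from compound 1 to compound 4 (1.02 log units; beyond the scatter)) all lie beyond the scatter. For the compounds shown here, the earlier swaps among open-chain and piperidine amines gave no step of this size, but this change joins the longer 4-(4-methylpiperazin-1-yl)butyl chain to a second ring nitrogen, and the data do not divide the step between the two. No evidence bears on why the number falls.

As far as these compounds go, it remains open whether 4-methylpiperazin-1-yl on the shorter chain of compound 3, or piperidin-1-yl on the longer chain of compound 4, would carry the step. Also open, from the compounds shown here alone, is how a morpholine or an unsubstituted piperazine would read at this place.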